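A few compounds are considered here, and "the series" means these few. Any claim that something is new, unique, unknown or untested is made for them only; others in the source may bear on it.

Measured compounds:
- Compound 1 `OC[C@H]1O[C@@H](n2cnc3c(NCc4ccccc4Br)ncnc32)[C@H](O)[C@@H]1O`: in a functional assay on G-361 cells (Homo sapiens) for antiproliferative activity, with a stated time of 72 h (on this read-out higher numbers stand for weaker inhibition and lower numbers for stronger inhibition), compound 1 reaches only the assay limit, > 166000 nM.
- Compound 2 `OC[C@H]1O[C@@H](n2cnc3c(NCc4ccc(Br)cc4)ncnc32)[C@H](O)[C@@H]1O`: in this assay compound 2 likewise sits at the limit, > 166000 nM.
- Compound 3 `Cc1cccc(CNc2ncnc3c2ncn3[C@@H]2O[C@H](CO)[C@@H](O)[C@H]2O)c1`: in this assay compound 3 also sits at the limit, > 166000 nM.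

Compound 1 therefore stands at the limit, as do the other two, which is all the numbers show (the limit of > 166000 nM in this assay, at which 3 of the 3 values shown sit). The three measured steps, a step that the two limits leave unreadable from compound 1 to compound 2, a step that the two limits leave unreadable from compound 1 to compound 3 and a step that the two limits leave unreadable from compound 2 to compound 3, cannot be sized. Compound 4 `COc1cccc(CNc2ncnc3c2ncn3[C@@H]2O[C@H](CO)[C@@H](O)[C@H]2O)c1O` differs from compound 1 by 2-hydroxy-3-methoxyphenyl in place of 2-bromophenyl on a saturated chain carbon bound to a nitrogen on an aromatic ring. Within the data shown here, no measured step bears on this change, so the step of a number no higher from compound 1 to compound 4 (the limit leaves the size open) is expected to be no more than the scatter, most likely another limit. Compound 4 is estimated at 166000 nM, within 50000 nM to 500000 nM.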

Compound 4, half-maximal inhibitory concentration: 148000 nM
Compound 4: middle estimate off by 1.1-fold (0.05 log units), on the high side; measured number inside the range.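

In this assay, the 2-hydroxy-3-methoxyphenyl group gives compound 4 a readable number, where the three other compounds give only a limit: the limit of > 166000 nM in this assay, at which 3 of the 4 values shown sit. The change gives an at least 1.1-fold lower number from compound 1 to compound 4 (0.04 log units; that floor lies within the scatter), an at least 1.1-fold lower number from compound 3 to compound 4 (0.04 log units; that floor lies within the scatter) and an at least 1.1-fold lower number from compound 2 to compound 4 (0.04 log units; that floor lies within the scatter). Each of these is only a floor, and the steps among compound 1, compound 2 and compound 3 cannot be read.

The compounds shown carry the hydroxy and methoxy groups only together, so what each does alone stays open. Also open, from the compounds shown here alone, is how an amine or a carboxylic acid on this phenyl ring would read in this assay.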